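Compound 3: cyclobutyl amide on a saturated chain

The source may report more compounds than this note shows. Statements on the series, on what has been measured and on what is new or still open speak of the compounds shown alone.

Two numbers are in hand for this series. In a functional assay on HepG2 cells (Homo sapiens) for inhibition, read by MTT assay, with a stated time of 120 h (a lower number here means a stronger inhibitor, a higher number a weaker inhibitor), compound 1 (`CC(NC(=O)/C=C/c1ccc(NC(=O)Nc2ccc(Cl)c(C(F)(F)F)c2)cc1)c1ccccc1`) gives 12200 nM. In this assay, compound 2 (`CNC(=O)/C=C/c1ccc(NC(=O)Nc2ccc(Cl)c(C(F)(F)F)c2)cc1`) gives 20400 nM. Going by the values given here, these two values lie within the scatter of each other, so compound 2 cannot be separated from compound 1, the only neighbour it has on the scale.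

The next structure is compound 3 (`O=C(CCc1ccc(NC(=O)Nc2ccc(Cl)c(C(F)(F)F)c2)cc1)NC1CCC1`). The change is 2-(cyclobutylcarbamoyl)ethyl in place of 2-(methylcarbamoyl)ethenyl on an aromatic carbon. In words, 2-(cyclobutylcarbamoyl)ethyl stands in place of 2-(methylcarbamoyl)ethenyl on an aromatic carbon, para to a large group.

Among the compounds with values here, one measured step bears on this, and only in part. In a 1.7-fold higher number from compound 1 to compound 2 (0.22 log units; within the scatter), the exchange of 1-phenylethyl for methyl on the amide nitrogen stays within the scatter, which suggests that the cyclobutyl part of the change need not move the number much. Within the data shown here, no measured step covers the loss of the double bond, so that part remains open and the range has to be wide.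

No shift beyond the scatter is expected, in either direction, and the expected step is a 1.3-fold lower number from compound 2 to compound 3 (0.11 log units; within the scatter). For compound 3 the estimated value is 16000 nM, with an expected range of 7000 nM to 38000 nM.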

Compound 3, half-maximal inhibitory concentration: > 50000 nM
Compound 3: a limit, no number (the forecaster's own chance of this, stated with the estimate: 10%); at least 3.1-fold (0.49 log units) between middle value and limit.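

In this assay, going by these compounds alone, the exchange of 2-(methylcarbamoyl)ethenyl for 2-(cyclobutylcarbamoyl)ethyl on the aromatic carbon gives an at least 2.4-fold higher number from compound 2 to compound 3 (0.38 log units; beyond the scatter), the first step beyond the scatter, whereas the exchange on the amide nitrogen gave a 1.7-fold higher number from compound 1 to compound 2 (0.22 log units; within the scatter). Compound 3 carries a limit of the assay and not a number, so the step gives only a lower bound on the change and no size for it: the limit of > 50000 nM in this assay, at which 1 of the 3 values shown sits. The change combines the loss of the chain double bond with cyclobutyl in place of methyl on the amide nitrogen, and the step cannot be divided between these two parts; the exchange on that nitrogen from compound 1 to compound 2 was read only with the double bond present.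

A 2-(methylcarbamoyl)ethyl or a 2-(cyclobutylcarbamoyl)ethenyl group on the same aromatic carbon would separate the two parts of the change. Also open, from the compounds shown here alone, is how this position responds to a group of another kind there, such as a carboxylic acid, an amine or a longer chain ending in an amide.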